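The source may report more compounds than this note shows. Statements on the series, on what has been measured and on what is new or still open speak of the compounds shown alone.

Measured in a functional assay on isolated protein for inhibition of Glucose-dependent insulinotropic receptor (Rattus norvegicus), read by HTRF and cAMP accumulation; on this read-out higher numbers stand for an effect only at larger amounts of compound and lower numbers for an effect already at smaller amounts:
compound 1 `Cc1nc(S(C)(=O)=O)ccc1Oc1ncnc(OC2CCN(C(=O)SC3CC3)CC2)c1F` gives 126 nM;
compound 2 `Cc1nc(S(C)(=O)=O)ccc1Oc1ncnc(OC2CCN(C(=O)SC3(C)CC3)CC2)c1F` gives 166 nM;
compound 3 `Cc1nc(S(C)(=O)=O)ccc1Oc1ncnc(OC2CCN(C(=O)C(F)(F)F)CC2)c1F` gives 880 nM.

Compound 3 stands at the highest number of the three, and both steps leading to it lie beyond the scatter: a 7.0-fold higher number from compound 1 to compound 3 (0.84 log units; beyond the scatter) and a 5.3-fold higher number from compound 2 to compound 3 (0.72 log units; beyond the scatter). Compound 4 `Cc1nc(S(C)(=O)=O)ccc1Oc1ncnc(OC2CCN(C(=O)C(C)(F)F)CC2)c1F` differs from compound 3 by methyl in place of fluoro on a saturated chain carbon bound to a carbonyl carbon and two fluorine atoms. Going by the values given here, no measured step exchanges fluoro for methyl on this chain carbon. Among the compounds with values here, the only methyl-for-hydrogen step, a 1.3-fold higher number from compound 1 to compound 2 (0.12 log units; within the scatter), sits on a saturated ring carbon and stays within the scatter, while the two larger steps replace the whole group on the carbonyl carbon and bear on compound 4 only loosely. The account therefore expects for compound 4 a modest move toward a lower number, a 1.5-fold lower number from compound 3 to compound 4 (0.17 log units; within the scatter), quite possibly within the scatter. The estimated value of compound 4 in this assay is 600 nM, with a range from 250 nM to 1500 nM.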

Compound 4, half-maximal effective concentration: 239 nM
Beside the measured number, compound 4's estimate is 2.5-fold (0.40 log units) above it; measured number below the stated range.
By their numbers in this assay, from the lowest: compounds 1, 2 and 4 (each within the scatter of the next); then compound 3.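

In this assay, going by these compounds alone, the single exchange of trifluoromethyl for 1,1-difluoroethyl gives a 3.7-fold lower number from compound 3 to compound 4 (0.57 log units; beyond the scatter), so one atom at this chain carbon moves the number beyond the scatter, which the earlier whole-group steps could not isolate. With this change, the group on the carbonyl carbon no longer stands apart from the sulfur-bearing groups, as a 1.4-fold higher number from compound 2 to compound 4 (0.16 log units; within the scatter) and a 1.9-fold higher number from compound 1 to compound 4 (0.28 log units; within the scatter) show. Nothing at hand accounts for this move. On these data alone, whether a 1-fluoroethyl, ethyl or 1,1-difluoropropyl group on the carbonyl carbon would give a similar number stays open.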